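Dihydrobenzodioxinyl for Methoxyphenyl: Fibroblast Cytotoxicity Outlook

The compounds below may be only part of what the source reports. "The series", "measured", "known", "first", "only" and "open" are said of these compounds alone.

Measured so far in an ADME assay on BJ cells (Homo sapiens) for cytotoxicity, read by CellTiter-Glo and resazurin assay, with a stated time of 72 h; on this read-out lower numbers stand for an effect already at smaller amounts and higher numbers for an effect only at larger amounts of compound:
Compound 1, `CC(=O)c1cccc(-c2ccc(C(=O)N(Cc3cccc(OCCCCCC(=O)O)c3)C(C)C)cc2)c1`, gives only a limit of the assay, > 26000 nM.
Compound 2, `CC(C)COc1cccc(-c2ccc(C(=O)N(Cc3cccc(OCCCCCC(=O)O)c3)C(C)C)cc2)c1`, gives only a limit of the assay, > 26000 nM.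
Compound 3, `COc1cccc(-c2ccc(C(=O)N(Cc3cccc(OCCCCCC(=O)O)c3)C(C)C)cc2)c1`, gives only a limit of the assay, > 20900 nM.

Compound 3 therefore stands at a limit and not at a number, and the same holds for both other measured compounds: two of the three values sit at the limit of > 26000 nM in this assay, at which 2 of the 3 values shown sit, and one at the limit of > 20900 nM in this assay, at which 1 of the 3 values shown sits. Compound 4, `CC(C)N(Cc1cccc(OCCCCCC(=O)O)c1)C(=O)c1ccc(-c2ccc3c(c2)OCCO3)cc1`, differs from compound 3 in one place: 2,3-dihydro-1,4-benzodioxin-6-yl in place of 3-methoxyphenyl on an aromatic carbon. Going by the values given here, the steps that bear on this change all alter the group on that same aromatic carbon, yet each of them connects two limits, so their size is not readable: a step that the two limits leave unreadable from compound 1 to compound 3, a step that the two limits leave unreadable from compound 2 to compound 3 and a step that the two limits leave unreadable from compound 1 to compound 2. With three limits and no readable step, the expectation for compound 4 in this assay is simply another limit, so the expected step is a step that the limit leaves unreadable from compound 3 to compound 4. Compound 4 is estimated at 30000 nM, with a range from 12000 nM to 100000 nM.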

Compound 4, half-maximal effective concentration: > 21900 nM
Compound 4: a limit, no number; the forecaster's own chance of this, stated with the estimate: 85%; the middle value does not contradict the limit.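

In this assay compound 4 gives > 21900 nM, a limit of the assay and not a number. Going by these compounds alone, as compound 1, compound 2 and compound 3 also stand at limits, no step to compound 4 can be read. The compounds shown leave open at what concentration any of them would reach a half-maximal effect on these cells.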